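From methoxy to isobutylamino on compound 1

The compounds below may be only part of what the source reports. "The series", "measured", "known", "first", "only" and "open" are said of these compounds alone.

In a functional assay for inhibition, with Rattus norvegicus as the target, at pH 7.35 (a higher number here means a weaker inhibitor, a lower number a stronger inhibitor), compound 1 (`CCC(NC(=O)C(CC(C)C)NC(=O)OCc1ccccc1)C(=O)C(=O)OC`) gives 280000 nM and stands highest of the three measured numbers. Nearest to it lies compound 3 (`CCOC(=O)C(=O)[C@H](CC)NC(=O)[C@H](CC(C)C)NC(=O)[C@H](CC(C)C)NC(=O)c1ccc2ccccc2c1`) at 78000 nM and furthest lies compound 2 (`CCOC(=O)C(=O)C(CC)NC(=O)C(CC(C)C)NC(=O)C(CC)Oc1ccccc1`) at 22000 nM on the same scale. Within the data shown here, both gaps lie beyond the scatter, but neither compound differs from compound 1 in one place only, so no measured pair isolates a single change.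

Next comes compound 4 (`CCC(NC(=O)C(CC(C)C)NC(=O)OCc1ccccc1)C(=O)C(=O)NCC(C)C`), with isobutylamino in place of methoxy on a carbonyl carbon. No measurement speaks to this change directly. Among the measured compounds shown here, the only guide is indirect: compound 2 reaches 22000 nM with other differences from compound 1 in place, so lower numbers are attainable. A moderate move toward a lower number in this assay is expected, and the estimated step of a 3.5-fold lower number from compound 1 to compound 4 (0.54 log units; beyond the scatter) carries wide uncertainty. For compound 4 the estimated value is 80000 nM (range 15000 nM to 400000 nM).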

Compound 4, half-maximal inhibitory concentration: 28000 nM
Compound 4: middle estimate off by 2.9-fold (0.46 log units), on the high side; the range from low to high includes it.
By their numbers in this assay, from the lowest: compounds 2 and 4 (each within the scatter of the next); then compound 3; then compound 1.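

Among these compounds, this is the first pair that differs in one place only: in this assay, isobutylamino in place of methoxy on a carbonyl carbon gives a 10-fold lower number from compound 1 to compound 4 (1.00 log units; beyond the scatter) with the rest of compound 1 unchanged. The position therefore responds to substitution, and a change from methoxycarbonyl to isobutylcarbamoyl alone is enough to produce a step beyond the scatter. No available data explain the size or direction of this step.

Going by these compounds, it remains open whether the step follows from the isobutyl chain or from the amide hydrogen; a dimethylamino group or an unsubstituted amino group on the same carbonyl carbon would help separate the two. The compounds shown also leave open whether the same change carries over to the cores of compound 2 and compound 3.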